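Pyrazole in place of the oxidised pyridine

The source may report more compounds than this note shows. Statements on the series, on what has been measured and on what is new or still open speak of the compounds shown alone.

Compound 1 `C[C@@H](O[C@H]1CN2C(=O)C=C(c3ccncc3)CC2[C@@H]1c1ccc(F)cc1)c1cc(C(F)(F)F)cc(C(F)(F)F)c1`: 8.1 nM
Compound 2 `C[C@@H](O[C@H]1CN2C(=O)C=C(c3cc[n+]([O-])cc3)CC2[C@@H]1c1ccc(F)cc1)c1cc(C(F)(F)F)cc(C(F)(F)F)c1`: 2.1 nM

Of the compounds shown here, two have been measured in an assay on CHO cells for displacement of a labelled ligand from Substance-P receptor (Homo sapiens), in the presence of a further agent that is not named here; a higher number here means a weaker inhibitor, a lower number a stronger inhibitor. Compound 1 gives 8.1 nM, and compound 2 gives 2.1 nM. For the measured compounds named here, compound 2 therefore has the lowest number of the two, and its only neighbour is compound 1, whose number is higher by a step that lies beyond the scatter: a 3.9-fold lower number from compound 1 to compound 2 (0.59 log units; beyond the scatter).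

Compound 3 `C[C@@H](O[C@H]1CN2C(=O)C=C(c3cnn(Cc4ccccc4)c3)CC2[C@@H]1c1ccc(F)cc1)c1cc(C(F)(F)F)cc(C(F)(F)F)c1` is not yet measured. It differs from compound 2 in one place: a group of 12 heavy atoms (10 carbon, 2 nitrogen; one five-membered aromatic ring with 2 hetero atoms, one six-membered aromatic ring of carbon only) in place of a group of 7 heavy atoms (5 carbon, 1 nitrogen, 1 oxygen; one six-membered aromatic ring with 1 hetero atom), on a double-bonded ring carbon. Going by the values given here, the only measured step that bears on this position is the one from compound 1 to compound 2, where the pendant ring was changed in a small way and the number moved by a 3.9-fold lower number from compound 1 to compound 2 (0.59 log units; beyond the scatter). That step shows the position tolerates change, but it gives no direct guide for a group of this larger kind. Compound 3 is therefore expected to fall near the two measured values, with a somewhat higher number than compound 2 estimated: a 4.8-fold higher number from compound 2 to compound 3 (0.68 log units; beyond the scatter). The estimate for compound 3 in this assay is 10 nM, with a range from 2 nM to 60 nM.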

Compound 3, half-maximal inhibitory concentration: 66 nM
Compound 3: the middle estimate sits 6.6-fold (0.82 log units) below what was measured, and the stated range ends below it.
By their numbers in this assay, from the lowest: compound 2; then compound 1; then compound 3.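

In this assay, the position on the double-bonded ring carbon turns out to be less forgiving than the earlier pair suggested. Setting 1-benzyl-1H-pyrazol-4-yl in place of pyridin-4-yl raises the number (an 8.1-fold higher number from compound 1 to compound 3 (0.91 log units; beyond the scatter)), and the same group set in place of the oxidised pyridine raises it further (a 31-fold higher number from compound 2 to compound 3 (1.50 log units; beyond the scatter)), so the small downward step seen earlier says little about a larger group with two aromatic rings at this carbon. No measurement shown accounts for this loss, and its cause remains unassigned.

What the compounds shown leave open is whether the loss belongs to the five-membered ring with two nitrogens or to the benzyl group it carries, a question that a 1-methyl-1H-pyrazol-4-yl group or an unsubstituted pyrazol-4-yl group at the same carbon would help to settle. As far as these compounds go, it is also open whether the six-membered aromatic ring of compound 2 is needed at all, which a plain phenyl or a pyridin-3-yl group there would begin to test.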